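The source may hold more compounds than are shown below. What is called first, only, known or untested is meant among the compounds shown, and "the series" means these compounds.

In an assay on RBL cells for inhibition of Polyunsaturated fatty acid 5-lipoxygenase (Rattus norvegicus) (on this read-out lower numbers stand for stronger inhibition and higher numbers for weaker inhibition), the measured compounds stand as follows:

compound 1 `CCCCCCCCCCc1cc2cc(C(C)N(O)C(C)=O)ccc2o1` — 410 nM
compound 2 `COc1cc(-c2cc3cc(C(C)N(O)C(C)=O)ccc3o2)cc(OC)c1OC` — 310 nM
compound 3 `CCOC(=O)CCC(=O)N(O)C(C)c1ccc2oc(-c3ccccc3)cc2c1` — 50 nM

Compound 2 holds the second highest of the three numbers. Its nearest neighbour is compound 1, whose number lies within the scatter of that of compound 2, so no order between these two is claimed. Compound 3 gives the lowest number, and the gap between compound 2 and compound 3 lies beyond the scatter.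

Compound 4 `COC(=O)CCCC(=O)N(O)C(C)c1ccc2oc(-c3cc(OC)c(OC)c(OC)c3)cc2c1` has not yet been measured. Against compound 2 the change is 2-(methoxycarbonyl)ethyl in place of hydrogen on a saturated chain carbon bound to a carbonyl carbon. Among the measured compounds shown here, no pair of measured compounds differs in this one place, so no measured step for it exists. What the numbers do show is that compound 3, which likewise carries an alkoxycarbonyl chain in place of the acetyl methyl, gives a number well below that of compound 2, while compound 1 and compound 2, differing at the ring substituent, sit within the scatter of each other. On that showing the step is expected to run downward and beyond the scatter, at a 4.4-fold lower number from compound 2 to compound 4 (0.65 log units; beyond the scatter). The basis is compound 3, which gives 50 nM. Compound 4 is estimated at 70 nM, with a range from 25 nM to 200 nM.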

Compound 4, half-maximal inhibitory concentration: 40 nM
The estimate for compound 4 lay 1.8-fold (0.24 log units) above the measured number, within the range that was stated.
By their numbers in this assay, from the lowest: compounds 4 and 3 (each within the scatter of the next); then compounds 2 and 1 (each within the scatter of the next).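

In this assay, 2-(methoxycarbonyl)ethyl in place of hydrogen on a saturated chain carbon bound to a carbonyl carbon gives a 7.8-fold lower number from compound 2 to compound 4 (0.89 log units; beyond the scatter). Among the compounds shown here, this is the first one-place reading at this position, and it shows that the acetyl group can give way to (3-(methoxycarbonyl)propyl)carbonyl with a lower number on this read-out, so the position accepts a chain of this size ending in methoxycarbonyl without loss. Nothing in hand accounts for the step, and this single pair gives its size but not its cause.

The compounds shown leave open whether the step belongs to the chain itself or to its methoxycarbonyl end, a question that a plain propyl chain or a carboxylic acid at the chain end would help to separate. One step also leaves open how the number follows chain length, and whether the same change on the core of compound 1 would give a step of similar size.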